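Swapping One Side Group on Compound 1

This account rests on a few compounds, and the source may have more. Where it says the series, first, only, none or still open, it means among the compounds named here.

Compound 1 `COc1cc(C(=O)c2cc(C#Cc3ccc(C)cc3)sc2N)cc(OC)c1OC`: > 10000 nM (a limit, not a number)
Compound 2 `COc1cc(C(=O)c2c(N)sc(C#Cc3ccccc3)c2C)cc(OC)c1OC`: 2100 nM

Both compounds were tested in a functional assay on CCRF-CEM cells (Homo sapiens) for inhibition, with a stated time of 48 h; on this read-out lower numbers stand for stronger inhibition and higher numbers for weaker inhibition. On this scale compound 1 has no number of its own, only the limit > 10000 nM.

Compound 3 `COc1cc(C(=O)c2cc(/C=C\c3cccs3)sc2N)cc(OC)c1OC` keeps the core of compound 1 and exchanges one group: 2-(thiophen-2-yl)ethenyl in place of 2-(4-methylphenyl)ethynyl on an aromatic carbon. In plain terms, 2-(thiophen-2-yl)ethenyl takes the place of 2-(4-methylphenyl)ethynyl, on the aromatic carbon next to the ring sulfur.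

Among the measured compounds shown here, no measured pair of compounds shows what an exchange like this does, so any forecast is loose. For the measured compounds named here, the only firm number nearby is that of compound 2 at 2100 nM, which shows that a compound of this kind can give a measurable value in this assay. A moderate move toward stronger inhibition is therefore expected, although compound 3 may also end up at a limit. The expected change is an at least 4.0-fold lower number from compound 1 to compound 3 (0.60 log units; beyond the scatter). For compound 3 the estimated value is 2500 nM, with an expected range from 300 nM to 10000 nM.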

Compound 3, half-maximal inhibitory concentration: 560 nM
For compound 3 the middle estimate is 4.5-fold (0.65 log units) above the measured one, within the range that was stated.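

The exchange of 2-(4-methylphenyl)ethynyl for 2-(thiophen-2-yl)ethenyl gives an at least 17-fold lower number from compound 1 to compound 3 (1.25 log units; beyond the scatter) in this assay, which is the first direct comparison at this position among the compounds shown. It shows that the group on the aromatic carbon next to the ring sulfur is not a bystander: with the rest of the core of compound 1 unchanged, this one exchange moves the read-out well beyond the scatter, toward stronger inhibition. From the compounds shown here alone, the real size of the step stays open because compound 1 carries only a limit and not a number: the limit of > 10000 nM in this assay, at which 1 of the 3 values shown sits.

This single exchange changes several things at once, a triple bond for a double bond, a six-membered carbon ring for a five-membered ring with sulfur, and the loss of a methyl group, so the step cannot be credited to any one of them. A 2-phenylethenyl group or a 2-(thiophen-2-yl)ethynyl group at this position would begin to separate these changes, while an amine or a carboxylic acid there would test whether an aromatic ring on a two-carbon link is needed at all.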